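Hydroxamate HDAC6 series: swapping the benzamide aryl group

The source may hold more compounds than are shown below. What is called first, only, known or untested is meant among the compounds shown, and "the series" means these compounds.

Measured compounds:
compound 1 `COc1cc(OC)cc(C(=O)N(CCC(=O)NCc2ccccc2)Cc2ccc(C(=O)NO)cc2)c1`: 26 nM
compound 2 `Cc1ccc(NC(=O)CCN(Cc2ccc(C(=O)NO)cc2)C(=O)c2ccccc2)cc1`: 10.7 nM
compound 3 `Cc1ccc(NC(=O)CCN(Cc2ccc(C(=O)NO)cc2)C(=O)c2ccc(N(C)C)cc2)cc1`: 19.5 nM

Of the compounds shown here, three sharing a common core have been tested in an assay on Sf9 cells for inhibition of protein deacetylase HDAC6 (Homo sapiens), read by fluorescence, with stated times of 90 min and 30 min; a lower number here means a stronger inhibitor, a higher number a weaker inhibitor. Compound 1 gives 26 nM, the highest of the three numbers; its nearest neighbour is compound 3 at 19.5 nM, a difference within the scatter, while the gap to compound 2 at 10.7 nM lies beyond it. Among the compounds with values here, the only step between compounds that differ in a single place is a 1.8-fold higher number from compound 2 to compound 3 (0.26 log units; within the scatter), which changes the group on the aryl ring attached to the carbonyl without moving the number beyond the scatter.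

Compound 4 `Cc1ccc(C(=O)N(CCC(=O)NCc2ccccc2)Cc2ccc(C(=O)NO)cc2)cc1` has not yet been measured. It differs from compound 1 in one place: 4-methylphenyl in place of 3,5-dimethoxyphenyl on a carbonyl carbon. Within the data shown here, no measured pair shows this exact exchange. Among the measured compounds shown here, the one step on that same aryl ring, from compound 2 to compound 3, stayed within the scatter, which gives no reason to expect a large move here. Compound 4 is therefore estimated at 18 nM, within the range 7 nM to 45 nM, meaning an expected step of a 1.4-fold lower number from compound 1 to compound 4 (0.16 log units; within the scatter) in this assay, a change not clearly beyond the scatter.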

Compound 4, half-maximal inhibitory concentration: 16.7 nM
The estimate for compound 4 lay 1.1-fold (0.03 log units) above the measured number; measured number inside the range.
By their numbers in this assay, from the lowest: compounds 2, 4, 3 and 1 (each within the scatter of the next, the first and the last beyond it).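

In this assay, the exchange on a carbonyl carbon whose other neighbour is an amide-type nitrogen gives a 1.6-fold lower number from compound 1 to compound 4 (0.19 log units; within the scatter), so replacing the whole 3,5-dimethoxyphenyl group with 4-methylphenyl stays as unresolved as the earlier single change on this ring. This step removes both counted hydrogen-bond acceptors and goes from 10 heavy atoms to 7, yet its size is no more telling than that of a 1.8-fold higher number from compound 2 to compound 3 (0.26 log units; within the scatter), which was measured with a different group on the other side of the shared core. Together, these two pairs show that neither change at this position moves the number beyond the scatter, although the claim reaches only these four compounds, and nothing available here bears on why the number responds so little.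

What the compounds shown leave open is whether a carboxylic acid or a primary amine on this aryl ring would give a step beyond the scatter. They also leave open whether a cyclohexyl group could take the place of the aryl ring on the same carbonyl carbon, and how any of these compounds would read against another deacetylase.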